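Removing a tert-Butoxycarbonyl Group on Two Related Anilides

This account rests on a few compounds, and the source may have more. Where it says the series, first, only, none or still open, it means among the compounds named here.

Compound 1 `CC(C)[C@H](NC(=O)c1cc(Cl)ccc1OCCCCNC(=O)OC(C)(C)C)C(=O)Nc1ccc([N+](=O)[O-])cc1Cl` carries a protected amine on a four-carbon chain. In a functional assay on MDA-MB-231 cells (Homo sapiens) for inhibition, read by MTT assay, with a stated time of 72 h (a higher number here means a weaker inhibitor, a lower number a stronger inhibitor), compound 1 gives > 10000 nM, which is a limit of the assay (the limit of > 10000 nM in this assay, at which 1 of the 3 values shown sits). Its deprotected partner, compound 2 `CC(C)[C@H](NC(=O)c1cc(Cl)ccc1OCCCCN)C(=O)Nc1ccc([N+](=O)[O-])cc1Cl`, gives 5590 nM in this assay. The change between them, (hydrogen in place of tert-butoxycarbonyl on an amine nitrogen), produced a step of an at least 1.7-fold lower number from compound 1 to compound 2 (0.25 log units; that floor lies within the scatter).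

Compound 3 `CC[C@@H](C)[C@H](NC(=O)c1cc(Cl)ccc1OCCNC(=O)OC(C)(C)C)C(=O)Nc1ccc([N+](=O)[O-])cc1Cl` belongs to a second pair; how its core differs from that of compound 1 is not broken down here. In this assay compound 3 gives 4020 nM. Compound 4 `CC[C@@H](C)[C@H](NC(=O)c1cc(Cl)ccc1OCCN)C(=O)Nc1ccc([N+](=O)[O-])cc1Cl` is the not yet measured member of that pair. The change from compound 3 to compound 4 is hydrogen in place of tert-butoxycarbonyl on an amine nitrogen, at a place described in the same words as before.

Resting on the earlier step of an at least 1.7-fold lower number from compound 1 to compound 2 (0.25 log units; that floor lies within the scatter), which itself only sets a floor that lies within the scatter, a modest lowering is expected, namely a 1.6-fold lower number from compound 3 to compound 4 (0.21 log units; within the scatter). Compound 4 is therefore estimated at 2500 nM in this assay, with a likely span from 1000 nM to 7000 nM.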

Compound 4, half-maximal inhibitory concentration: 6180 nM
The estimate for compound 4 lay 2.5-fold (0.39 log units) below the measured number; the measured number falls inside the stated range.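

In this assay, putting hydrogen in place of tert-butoxycarbonyl on the amine nitrogen gives a 1.5-fold higher number from compound 3 to compound 4 (0.19 log units; within the scatter), so on this core the change has no effect that can be told from the scatter. Set beside the earlier pair, the same change does not carry over as one fixed step from one core to the other: the same change on two cores in this assay, an at least 1.7-fold lower number (0.25 log units; that floor lies within the scatter) from compound 1 to compound 2 and a 1.5-fold higher number (0.19 log units; within the scatter) from compound 3 to compound 4, at least 2.7-fold (0.43 log units) apart, beyond the scatter of two such steps This does not give the true size of the earlier step, for compound 1 sits at a limit of the assay, and it does not tie the gap to any one part of the two cores, which differ from each other in more than one place: the limit of > 10000 nM in this assay, at which 1 of the 4 values shown sits.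

The compounds shown leave open whether the free amine and its protected form would separate on a single core carrying a shorter or a longer chain. They also leave open how an acetyl group or a carboxylic acid at the end of the chain would compare with the amine.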